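Methylsulfonyl for Propoxy: Expected Cytotoxicity of Compound 4

The source may report more compounds than this note shows. Statements on the series, on what has been measured and on what is new or still open speak of the compounds shown alone.

Measured in an ADME assay on BJ cells (Homo sapiens) for cytotoxicity, read by luminescence, with a stated time of 72 h; a higher number here means that more compound is needed for the effect, a lower number that less compound is needed:
- compound 1 `CCOC(=O)c1c(-c2cccc(OC)c2)[nH]c2cc(OC)ccc2c1=O` gives only a limit, > 21500 nM.
- compound 2 `CCCOc1cccc(-c2[nH]c3cc(OC)ccc3c(=O)c2C(=O)OCC)c1` gives only a limit, > 21500 nM.
- compound 3 `CCOC(=O)c1c(-c2cccc(OC(C)C)c2)[nH]c2cc(OC)ccc2c1=O` gives only a limit, > 21500 nM.

Compound 2 stands at the same limit as the other two values, since (the limit of > 21500 nM in this assay, at which 3 of the 3 values shown sit). The steps among the measured compounds, a step that the two limits leave unreadable from compound 1 to compound 2, a step that the two limits leave unreadable from compound 1 to compound 3 and a step that the two limits leave unreadable from compound 2 to compound 3, therefore cannot be read. Compound 4 `CCOC(=O)c1c(-c2cccc(S(C)(=O)=O)c2)[nH]c2cc(OC)ccc2c1=O` differs from compound 2 in one place: methylsulfonyl in place of propoxy on an aromatic carbon. Within the data shown here, no measured step bears on this change directly; the shared core has so far stayed at the limit whatever the alkoxy group. Compound 4 is therefore expected to stay near the limit, with a step that the limit leaves unreadable from compound 2 to compound 4 estimated. The estimate for compound 4 is 30000 nM, ranging from 10000 nM to 100000 nM.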

Compound 4, half-maximal effective concentration: > 21500 nM
Compound 4: only a limit was reported (the forecaster's own chance of this, stated with the estimate: 85%); the middle value does not contradict the limit.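

Compound 4 gives only a limit in this assay, as compound 1, compound 2 and compound 3 do, so no step among them can be read: the limit of > 21500 nM in this assay, at which 4 of the 4 values shown sit.

Going by these compounds, how far these compounds lie past that limit, and so whether methylsulfonyl and the alkoxy groups differ at all, stays open.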